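Swapping the Acid Tail for a Protected Pyrrolidine

The source may report more compounds than this note shows. Statements on the series, on what has been measured and on what is new or still open speak of the compounds shown alone.

Within the data shown here, the series is built on a shared core that carries a piperidine amide; the two measured members differ only in the group attached to the carbonyl carbon of that amide. Compound 1 `O=C(c1cccnc1)N1CCC(NS(=O)(=O)c2cc(S(=O)(=O)c3ccccc3)ccc2C(F)(F)F)CC1` carries a pyridin-3-yl group there, and in an assay on U2OS cells for inhibition of secreted frizzled-related protein 1 (Homo sapiens), read by a luciferase reporter, with a stated time of 18 h (a lower number here means that less compound is needed, a higher number that more compound is needed for the effect), compound 1 gives 120 nM. Compound 2 `O=C(O)CCCC(=O)N1CCC(NS(=O)(=O)c2cc(S(=O)(=O)c3ccccc3)ccc2C(F)(F)F)CC1` carries a 3-carboxypropyl group instead, and in this assay compound 2 gives 570 nM. Among the measured compounds shown here, that single change produced a 4.8-fold higher number from compound 1 to compound 2 (0.68 log units; beyond the scatter), so compound 2 holds the higher of the two numbers measured so far.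

Compound 3 `CC(C)(C)OC(=O)N1CCC[C@H]1C(=O)N1CCC(NS(=O)(=O)c2cc(S(=O)(=O)c3ccccc3)ccc2C(F)(F)F)CC1` has not yet been measured. It differs from compound 2 by 1-(tert-butoxycarbonyl)pyrrolidin-2-yl in place of 3-carboxypropyl on a carbonyl carbon. For the measured compounds named here, the one measured step bears on this directly: removing the pyridin-3-yl group in favour of the acid-bearing chain raised the number, and compound 3 now removes that same chain again. The expectation is therefore a lower number for compound 3 than for compound 2, a step of a 3.8-fold lower number from compound 2 to compound 3 (0.58 log units; beyond the scatter) in this assay, of a size like the measured one but reversed in direction. On that basis compound 3 is estimated at 150 nM in this assay, with a plausible range from 40 nM to 600 nM.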

Compound 3, half-maximal effective concentration: 60 nM
Beside the measured number, compound 3's estimate is 2.5-fold (0.40 log units) above it; measured number inside the range.
By their numbers in this assay, from the lowest: compounds 3 and 1 (each within the scatter of the next); then compound 2.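

In this assay, 1-(tert-butoxycarbonyl)pyrrolidin-2-yl on the carbonyl carbon gives a 9.5-fold lower number from compound 2 to compound 3 (0.98 log units; beyond the scatter) and so shows that this position accepts a group of 12 heavy atoms, against 6 heavy atoms in the 3-carboxypropyl it replaces, with a ring and a defined stereocentre, and no loss in the number. Set against the pyridin-3-yl of compound 1, the same group gives a 2.0-fold lower number from compound 1 to compound 3 (0.30 log units; within the scatter) and so stays within the scatter, which leaves compound 1 and compound 3 level and makes compound 2 the only one of the three set apart by its number. Nothing at hand accounts for these steps at this position.

The compounds shown leave open whether the number follows the tert-butoxycarbonyl group or the pyrrolidine ring itself, a question that the free pyrrolidine amine or the opposite configuration at the stereocentre would address. They also leave open whether the carboxylic acid or the chain carrying it sets compound 2 apart, which a methyl ester on the same chain would help to separate.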